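Removing a chloro from a hydrazone: what the change costs

The source may hold more compounds than are shown below. What is called first, only, known or untested is meant among the compounds shown, and "the series" means these compounds.

Of the compounds shown here, two have been tested in a functional assay on HCT-15 cells (Homo sapiens) for antiproliferative activity, read by sulforhodamine B assay, with a stated time of 48 h; on this read-out lower numbers stand for stronger inhibition of growth and higher numbers for weaker inhibition of growth. Compound 1 `COc1ccc(OC)c(/C=C/c2nnc(Nc3ccc(Cl)cc3)o2)c1` gives 34100 nM, whereas compound 2 `COc1ccc(OC)c(/C=C/C(=O)N/N=C/c2ccc(Cl)cc2)c1` gives 83.5 nM, the lowest of the two numbers; compound 1 sits a long way above it, well beyond the usual scatter. Compound 3 `COc1ccc(OC)c(/C=C/C(=O)N/N=C/c2ccccc2)c1` is the next compound, not yet measured, and differs from compound 2 by a single change: hydrogen in place of chloro on an aromatic carbon. The step from compound 2 to compound 3 is expected to be a modest rise in this assay, a 2.6-fold higher number from compound 2 to compound 3 (0.42 log units; beyond the scatter), probably past the scatter. Compound 3 is therefore estimated to give 220 nM, with a likely range from 60 nM to 800 nM.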

Compound 3, concentration for 50% growth inhibition: 3620 nM
Compound 3: middle estimate off by 16-fold (1.22 log units), on the low side; the measured number lies above the stated range.
By their numbers in this assay, from the lowest: compound 2; then compound 3; then compound 1.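

In this assay, hydrogen in place of chloro on the aromatic ring gives a 43-fold higher number from compound 2 to compound 3 (1.64 log units; beyond the scatter) and so shows that this position is highly sensitive to the change, with a single heavy atom accounting for a large step. The earlier comparison between compound 1 and compound 2 could not show this, as those two differ in more than one place. Nothing measured here explains the size of this step.
Going by these compounds, whether chloro is special at this position remains open. A fluoro, a bromo or an amine in the same place would help to settle that.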